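The source may hold more compounds than are shown below. What is called first, only, known or untested is meant among the compounds shown, and "the series" means these compounds.

Compound 1 `CCc1ccc(NC(=O)Nc2cc(C)nc3ccccc23)cc1`: > 25000 nM (a limit)
Compound 2 `COC(=O)c1ccc(NC(=O)Nc2cc(C)nc3ccccc23)cc1`: 21000 nM
Compound 3 `Cc1cc(NC(=O)Nc2ccc(N)cc2)c2ccccc2n1`: > 25000 nM (a limit)

All three compounds were tested in an ADME assay on BJ cells (Homo sapiens) for cytotoxicity, with a stated time of 72 h; a lower number here means that less compound is needed, a higher number that more compound is needed for the effect. Compound 3 gives only a limit, > 25000 nM, and not a number. This is the limit of > 25000 nM in this assay, at which 2 of the 3 values shown sit.

Compound 4 `Cc1cc(NC(=O)Nc2ccc(C(=O)O)cc2)c2ccccc2n1` carries carboxy in place of amino on an aromatic carbon, para to a large group (carboxy in place of amino on an aromatic carbon).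

Two measured steps change a group at this same place. One is an at least 1.1-fold higher number from compound 2 to compound 3 (0.07 log units; that floor lies within the scatter), the other at least 1.1-fold lower number from compound 1 to compound 2 (0.07 log units; that floor lies within the scatter). The third step, a step that the two limits leave unreadable from compound 1 to compound 3, gives no size to work with. Neither readable step goes beyond the scatter, so no step beyond the scatter is expected in this assay. Among the compounds with values here, this expectation leans on compound 2, whose 21000 nM is the only true number in the set.

For compound 4 the estimated value is 25000 nM, with an expected range of 14000 nM to 40000 nM. This estimate means an expected step of a number no higher from compound 3 to compound 4 (the limit leaves the size open).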

Compound 4, half-maximal effective concentration: > 25000 nM
Compound 4: no number, only a limit (the forecaster's own chance of this, stated with the estimate: 65%); the middle value sits exactly at the limit.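

In this assay compound 4 gives only a limit and not a number, so a carboxy group at this place joins ethyl and amino in reaching it. Within the data shown here, removing the methyl from the ester of compound 2 gives an at least 1.1-fold higher number from compound 2 to compound 4 (0.07 log units; that floor lies within the scatter), and only this floor on the step is known, so the real size stays open. The steps linking compound 4 to compound 1 and compound 3 cannot be read, because both members of each pair sit at the same limit: the limit of > 25000 nM in this assay, at which 3 of the 4 values shown sit.

Where the true values of compound 1, compound 3 and compound 4 lie remains open, leaving compound 2 as the only true number. Also open, from the compounds shown here alone, is how a nitrile or a longer chain at this place would read, and whether either would give a number clearly below the limit.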